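Replacing a phenoxy tail with a trifluorophenyl tail: permeability

A few compounds are considered here, and "the series" means these few. Any claim that something is new, unique, unknown or untested is made for them only; others in the source may bear on it.

Measured so far:
compound 1, `Cc1c(F)cccc1CCCCOc1ccc(/C=C/c2cccc3c(CCCC(=O)O)c(C)n(CC(=O)O)c23)cc1`, 1.5 10^-6 cm/s
compound 2, `O=C(O)CCCc1cn(CC(=O)O)c2c(/C=C/c3ccc(OCCCCOc4ccccc4)cc3)cccc12`, < 0.05 10^-6 cm/s

Of the compounds shown here, two have been tested in a physicochemical assay for permeability, using PAMPA, with a stated time of 4 h, at pH 7.4, tested at 50 uM; a lower number here means that the compound crosses the layer more slowly, a higher number that the compound crosses the layer faster. Compound 1 gives 1.5 10^-6 cm/s. For compound 2 the read-out is only a limit of the assay, < 0.05 10^-6 cm/s, so no number is known for it; (the limit of < 0.05 10^-6 cm/s in this assay, at which 1 of the 2 values shown sits).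

Compound 3, `O=C(O)CCCc1cn(CC(=O)O)c2c(/C=C/c3ccc(OCCCCc4c(F)ccc(F)c4F)cc3)cccc12`, has not yet been measured. It differs from compound 2 in one place: 2,3,6-trifluorophenyl in place of phenoxy on a saturated chain carbon, four bonds along the chain from an oxygen on an aromatic ring. Going by the values given here, no step between two measured compounds covers this change, so its size can only be guessed. Compound 3 shares its carbon-linked aryl tail with compound 1, which gives a number rather than a limit, while compound 2 sits at the limit. The step of an at least 10-fold higher number from compound 2 to compound 3 (1.00 log units; beyond the scatter) is therefore expected to run upward, likely beyond the scatter. Compound 3 is estimated to give 0.5 10^-6 cm/s, within a range from 0.08 10^-6 cm/s to 2.5 10^-6 cm/s.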

Compound 3, apparent permeability: < 0.05 10^-6 cm/s
Compound 3: only a limit was reported; the forecaster's own chance of this, stated with the estimate: 25%; at least 10-fold (1.00 log units) between middle value and limit.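

In this assay, compound 2 and compound 3 both give only a limit, so no step between them can be read: the limit of < 0.05 10^-6 cm/s in this assay, at which 2 of the 3 values shown sit.

The compounds shown leave open whether 2,3,6-trifluorophenyl in place of phenoxy changes the read-out at all, and by how much.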